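Piperidinyl to methyl on the pyrazole in two series

The compounds below may be only part of what the source reports. "The series", "measured", "known", "first", "only" and "open" are said of these compounds alone.

compound 1 `CC(Nc1ncnc2ncc(-c3cnn(C4CCNCC4)c3)cc12)c1c(Cl)ccc(F)c1Cl` 7110 nM
compound 2 `CC(Nc1ncnc2ncc(-c3cnn(C)c3)cc12)c1c(Cl)ccc(F)c1Cl` > 100000 nM
compound 3 `c1cnc2ccc(Nc3ncnc4ccc(-c5cnn(C6CCNCC6)c5)cc34)cc2c1` 30300 nM

In a functional assay on MDA-MB-231 cells (Homo sapiens) for antiproliferative activity, read by MTT assay, with a stated time of 72 h (on this read-out higher numbers stand for weaker inhibition and lower numbers for stronger inhibition), compound 1 gives 7110 nM. Compound 2 reaches only a limit of the assay, > 100000 nM. The change methyl in place of piperidin-4-yl on an aromatic nitrogen produced an at least 14-fold higher number from compound 1 to compound 2 (1.14 log units; beyond the scatter), a step whose full size is hidden by the limit of > 100000 nM in this assay, at which 1 of the 3 values shown sits. Compound 3 gives 30300 nM; the difference between its core and the core of compound 1 is not broken down here. Compound 4 `Cn1cc(-c2ccc3ncnc(Nc4ccc5ncccc5c4)c3c2)cn1` carries the same change, (methyl in place of piperidin-4-yl on an aromatic nitrogen). Because the step of an at least 14-fold higher number from compound 1 to compound 2 (1.14 log units; beyond the scatter) already ran past the limit from a lower starting number, compound 4 is expected to show a step of similar or larger size, a 9.9-fold higher number from compound 3 to compound 4 (1.00 log units; beyond the scatter), and most likely to be reported only as a limit. The estimate for compound 4 is 300000 nM, from 80000 nM to 1500000 nM.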

Compound 4, half-maximal inhibitory concentration: 26300 nM
For compound 4 the middle estimate is 11-fold (1.06 log units) above the measured one, outside the stated range (below it).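

In this assay, methyl in place of piperidin-4-yl on an aromatic nitrogen gave a 1.2-fold lower number from compound 3 to compound 4 (0.06 log units; within the scatter). The change therefore did not carry over with the same effect from one core to the other: the same change on two cores in this assay, an at least 14-fold higher number (1.14 log units; beyond the scatter) from compound 1 to compound 2 and a 1.2-fold lower number (0.06 log units; within the scatter) from compound 3 to compound 4, at least 16-fold (1.20 log units) apart, beyond the scatter of two such steps. Compound 2 stands only at a limit, so the full step on the core of compound 1 cannot be read, and these numbers do not show what sets the two cores apart: the limit of > 100000 nM in this assay, at which 1 of the 4 values shown sits.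

The compounds shown leave open how an aminoethyl chain in place of piperidin-4-yl would behave on these two cores. They also leave open whether a further core would follow the step to compound 2 or the step to compound 4.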